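Swapping Bromine for Chlorine on a Benzamide Side Chain

The source may report more compounds than this note shows. Statements on the series, on what has been measured and on what is new or still open speak of the compounds shown alone.

Measured so far, in a functional assay on A549 cells (Homo sapiens) for inhibition, read by CCK-8 assay, with a stated time of 72 h, tested at 8 uM; on this read-out higher numbers stand for more inhibition of growth at the one concentration tested and lower numbers for less inhibition of growth:
compound 1, `COc1ccc(SCc2ccc(/C=C/C(=O)Nc3ccccc3N)cc2)cc1OC`, gives 80.6%
compound 2, `Nc1ccccc1NC(=O)c1ccc(CSc2ccc(Br)cc2)cc1`, gives 45.7%

Of the compounds shown here, two have been measured in this assay. Compound 1 gives 80.6%, the higher of the two numbers. Compound 2 gives 45.7%, the lowest of the two, and the gap to compound 1 lies beyond the scatter of the method. For the measured compounds named here, the two structures differ in several places at once, so no single step between measured compounds is available to show how one change alone moves the read-out.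

Compound 3, `Nc1ccccc1NC(=O)c1ccc(CSc2ccc(Cl)cc2)cc1`, is the next candidate. It differs from compound 2 by chloro in place of bromo on an aromatic carbon. Nothing in the measured pair tells how a change of this kind behaves in this assay. One halogen replaces another of similar character in the same place, so the expectation is a step of a number 2.7 percentage points lower from compound 2 to compound 3 (within the scatter), that is, no change beyond the scatter. Compound 3 is therefore estimated at 43%, with a range from 28% to 58%.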

Compound 3, percent growth inhibition at one concentration: 50.4%
Estimate against measurement, compound 3: 7.4 percentage points below; the range from low to high includes it.
By their numbers in this assay, from the lowest: compounds 2 and 3 (each within the scatter of the next); then compound 1.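

In this assay, replacing 4-bromophenyl with 4-chlorophenyl gives a number 4.7 percentage points higher from compound 2 to compound 3 (within the scatter), so at this place, on an aromatic carbon para to a large group, the two halogens cannot be told apart by this read-out. For the compounds shown here, this is the first comparison in the set in which only one place changes, whereas compound 1 differs from compound 2 in several places at once and could not show the effect of any single change. Nothing available here bears on what lies behind this result.

Going by these compounds, a single swap between two halogens says little about how far this position can be varied, so it remains open whether an amine or a carboxylic acid in the same place would leave the read-out unchanged or move it beyond the scatter. Compound 1 also differs from compound 3 in several places, so the present compounds cannot show which of those differences goes with the value of compound 1, 80.6%, and a series changing them one at a time would be needed to separate them.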